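Working notes: the step from compound 3 to compound 4

The source may report more compounds than this note shows. Statements on the series, on what has been measured and on what is new or still open speak of the compounds shown alone.

Measured compounds:
compound 1 `CCCOC(=O)C1=C(C)NC(=O)NC1c1ccoc1`: 50%
compound 2 `CC1=C(C(=O)CC(C)C)C(c2ccoc2)NC(=O)N1`: 23%
compound 3 `CCSC(=O)C1=C(C)NC(=O)NC1c1ccoc1`: 3%

In an assay on membranes from CHO cells for displacement of a labelled ligand from adenosine receptor A1 (Homo sapiens), read by scintillation counting, with a stated time of 60 min, tested at 1 uM (a higher number here means more inhibition at the concentration tested (going by the name of the read-out), a lower number less inhibition), compound 3 has the lowest of the three numbers; its nearest neighbour is compound 2, a number 20 percentage points lower from compound 2 to compound 3 (beyond the scatter), and the furthest is compound 1, a number 47 percentage points lower from compound 1 to compound 3 (beyond the scatter).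

Compound 4 `CC1=C(c2ncc(C)o2)C(c2ccoc2)NC(=O)N1` differs from compound 3 by 5-methyl-1,3-oxazol-2-yl in place of (ethylsulfanyl)carbonyl on a double-bonded ring carbon. Among the compounds with values here, no measured step bears directly on this change: a number 27 percentage points lower from compound 1 to compound 2 (beyond the scatter), a number 47 percentage points lower from compound 1 to compound 3 (beyond the scatter) and a number 20 percentage points lower from compound 2 to compound 3 (beyond the scatter) each exchange only the group on a carbonyl carbon, whereas here the (ethylsulfanyl)carbonyl leaves altogether. Those steps show merely that variation at this ring carbon moves this assay by modest to large amounts. A modest rise toward the level of compound 1 is therefore expected, with a wide range, so that compound 4 is estimated at 20% (range 0% to 55%), an expected step of a number 17 percentage points higher from compound 3 to compound 4 (beyond the scatter).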

Compound 4, a percentage reported as inhibition, at one concentration (the size of the read-out at that concentration, not a potency): 21%
For compound 4 the middle estimate is 1 percentage points below the measured one, within the range that was stated.
By their numbers in this assay, from the lowest: compound 3; then compounds 4 and 2 (each within the scatter of the next); then compound 1.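

In this assay a carbonyl on this double-bonded ring carbon proves dispensable: 5-methyl-1,3-oxazol-2-yl, which has none, gives a number 18 percentage points higher from compound 3 to compound 4 (beyond the scatter) in exchange for (ethylsulfanyl)carbonyl. In exchange for isobutylcarbonyl it gives a number 2 percentage points lower from compound 2 to compound 4 (within the scatter), so these two groups cannot be told apart here, while exchange for propoxycarbonyl gives a number 29 percentage points lower from compound 1 to compound 4 (beyond the scatter), leaving the ester of compound 1 ahead of the oxazole. No available evidence accounts for these differences. Still open, on these data alone, is how an amide built from an amine, a longer alkoxy chain than propoxy, or 1,3-oxazol-2-yl without its methyl would read at this carbon in this assay.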